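A few compounds are considered here, and "the series" means these few. Any claim that something is new, unique, unknown or untested is made for them only; others in the source may bear on it.

Compound 1, `N#Cc1ccc(C(=O)Nc2ccc(Cl)c(-c3nc4ccccc4[nH]3)c2)cc1`, is the reference point of this small set. In a functional assay on Shh Light II cells for inhibition of Sonic hedgehog protein (Mus musculus), read by reporter gene assay, with a stated time of 48 h, in the presence of a further agent that is not named here (a higher number here means a weaker inhibitor, a lower number a stronger inhibitor), compound 1 gives 185 nM, the highest number among the two compounds that returned one. Compound 2, `COc1cc(C(=O)Nc2ccc(Cl)c(-c3nc4ccccc4[nH]3)c2)cc(OC)c1OC`, is the nearest neighbour: in this assay compound 2 gives 79.8 nM, a lower number than compound 1 by a margin that lies beyond the scatter of repeated measurements. Compound 3, `CCOc1cc(C(=O)Nc2ccc(Cl)c(-c3nc4ccccc4o3)c2)cc(OCC)c1OCC`, returned no number at all; in this assay compound 3 is recorded as "not active" (no number reported). No pair among these three differs in only one place, so no single step can be read off the measured compounds.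

The next compound, compound 4, `O=C(Nc1ccc(Cl)c(-c2nc3ccccc3[nH]2)c1)c1ccc(Cl)cc1`, is compared with compound 1 directly. The difference is chloro in place of cyano on an aromatic carbon. The cyano group leaves and a chloro group enters at the same aromatic carbon, para to a large group; read one bond further out, a 4-cyanophenyl becomes a 4-chlorophenyl.

Nothing measured here anchors this exchange, so the step of a 1.1-fold lower number from compound 1 to compound 4 (0.04 log units; within the scatter) is an expectation only, and a small one: no movement beyond the scatter in either direction is expected. Compound 4 is therefore expected to give about 170 nM in this assay, with a range from 55 nM to 550 nM.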

Compound 4, half-maximal inhibitory concentration: 224 nM
Compound 4: middle estimate off by 1.3-fold (0.12 log units), on the low side; the range from low to high includes it.
By their numbers in this assay, from the lowest: compound 2; then compounds 1 and 4 (each within the scatter of the next).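

In this assay, going by these compounds alone, chloro in place of cyano on an aromatic carbon gives a 1.2-fold higher number from compound 1 to compound 4 (0.08 log units; within the scatter), the first step that can be read at a single place. At this aromatic carbon, para to a large group, the 4-cyanophenyl and the 4-chlorophenyl therefore cannot be told apart, and the nitrile with its triple bond and hydrogen-bond acceptor is not needed for a number of this size: compound 4, whose entering chloro counts no hydrogen-bond acceptor, gives 224 nM on the shared core. No measurement on hand bears on why the two groups read alike at this position.

From the compounds shown here alone, whether an amine, a carboxylic acid or a longer chain on the same aromatic carbon would move the number beyond the scatter remains open, as does the reach of this single exchange on other cores. Compound 3 differs from compound 1 and compound 4 in more than one place, so its "not active" record cannot yet be tied to any single one of those differences.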